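This account rests on a few compounds, and the source may have more. Where it says the series, first, only, none or still open, it means among the compounds named here.

Compound 1 `NC(=O)C1CCN(c2nc(-c3ccccn3)nc3c2CN(Cc2ccccc2)CC3)CC1` and compound 2 `CN(C)CCN1CCN(c2nc(-c3ccccn3)nc3c2CN(Cc2ccccc2)CC3)CC1` share a core that carries a benzyl group on the ring amine nitrogen. In an assay on A549 cells with Cystic fibrosis transmembrane conductance regulator variant F508del (Homo sapiens) as the target, read by fluorescence, with a stated time of 25 min (a higher number here means a larger maximal response, a lower number a smaller maximal response), compound 1 gives 34.4%, and compound 2 gives 57%; the exchange at the aromatic carbon produced a number 22.6 percentage points higher from compound 1 to compound 2 (beyond the scatter). Compound 3 `CN(C)CCN1CCN(c2nc(-c3ccccn3)nc3c2CN(Cc2ccsc2)CC3)CC1` keeps the side group of compound 2 but carries (thiophen-3-yl)methyl on the ring amine nitrogen, and in this assay compound 3 was reported as "not active" (no number reported), so no single number stands for it. Compound 4 `CN(C)CCN1CCN(c2nc(-c3ccccn3)nc3c2CN(C(=O)c2ccccc2)CC3)CC1` differs from compound 3 in one place: benzoyl in place of (thiophen-3-yl)methyl on an amine nitrogen in a ring. Within the data shown here, no measured step touches this ring amine nitrogen; the only measured step, from compound 1 to compound 2, concerns a different position and tells nothing about a change here. Going by these compounds, what can be said is that compound 1 and compound 2, with benzyl at that nitrogen, gave measurable responses, while compound 3, with (thiophen-3-yl)methyl there, did not, so the group on this nitrogen clearly matters, but the direction for benzoyl is unknown. The maximal response of compound 4 in this assay is therefore estimated at 20%, with a wide expected range from 0% to 50%, and a real chance that it too is reported only as inactive.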

Compound 4, largest response reached (Emax), in percent of the reference or control that the assay uses: "not active" (no number reported)
The entry for compound 4 holds no number; there is nothing to compare the estimate with.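

Compound 3 and compound 4 were both reported as not active, with no number for either, so no step can be read between them. Nothing here offers an explanation for this result. Left open is how large any difference in maximal response between (thiophen-3-yl)methyl and benzoyl on the ring amine nitrogen might be.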